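The source may hold more compounds than are shown below. What is called first, only, known or untested is meant among the compounds shown, and "the series" means these compounds.

Series in a functional assay on SW480 cells (Homo sapiens) for antiproliferative activity, read by MTT assay, with a stated time of 48 h; a higher number here means a weaker inhibitor, a lower number a stronger inhibitor:
- compound 1 `CCCCC(CCO)n1cnc2c(OC)ncnc21` gives > 50000 nM (a limit)
- compound 2 `CCCCCC(CCO)n1cnc2c(Cl)nc(Cl)nc21` gives 6010 nM
- compound 3 `CCCCCC(CCO)n1cnc2c(OC)ncnc21` gives > 50000 nM (a limit)
- compound 4 `CCCCCC(CCO)n1cnc2c(N)ncnc21` is not yet measured

Compound 3 has no number, since its > 50000 nM is a limit. Compound 3 thus sits at the limit of > 50000 nM in this assay, at which 2 of the 3 values shown sit. Within the data shown here, compound 2 gives 6010 nM, the only value that is not a limit.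

The next change leads to compound 4: amino in place of methoxy on an aromatic carbon. Among the measured compounds shown here, the only measured step between compounds differing in one place is a step that the two limits leave unreadable from compound 1 to compound 3. It lies on the saturated chain, not at this aromatic carbon, and offers no size to carry over. The expectation therefore rests on the limit shared by most of the series: little change, and quite possibly another limit. The expected step is an at least 1.2-fold lower number from compound 3 to compound 4 (0.09 log units; that floor lies within the scatter), estimated as modest and toward stronger inhibition if it can be read at all. For compound 4 the estimated value in this assay is 40000 nM, with an expected range from 12000 nM to 80000 nM.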

Compound 4, half-maximal inhibitory concentration: > 50000 nM
Compound 4 gave a limit, no number; the forecaster's own chance of this, stated with the estimate: 60%; middle value at least 1.2-fold (0.09 log units) from the limit.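

In this assay compound 4 gives > 50000 nM, a limit. Compound 3 is also a limit, so the step between compound 3 and compound 4 cannot be read. The compounds shown leave open whether amino and methoxy differ at this aromatic carbon in this assay.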